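This account rests on a few compounds, and the source may have more. Where it says the series, first, only, none or still open, it means among the compounds named here.

Measured so far: compound 1 `Cc1ccc(Nc2nc(SCc3cn(CC(=O)NC(=O)Nc4ccccn4)nn3)nc(-c3ccc(C)cc3)c2C#N)cc1` gives 39600 nM in a functional assay on MCF7 cells (Homo sapiens) for inhibition, read by MTT assay, with a stated time of 72 h; a lower number here means a stronger inhibitor, a higher number a weaker inhibitor; compound 2 `Cc1ccc(-c2nc(SCc3cn(CC(=O)NC(=O)Nc4ccccn4)nn3)nc(Nc3cccc(Cl)c3)c2C#N)cc1` gives 14900 nM.

Compound 1 has the highest number of the two, and the step of a 2.7-fold lower number from compound 1 to compound 2 (0.42 log units; beyond the scatter) comes from a change on the nitrogen-linked ring, not from the part changed here. Compound 3 `Cc1ccc(Nc2nc(SCc3cn(CC(=O)NC(=O)Nc4ccccn4)nn3)nc(-c3ccccc3)c2C#N)cc1` differs from compound 1 by hydrogen in place of methyl on an aromatic carbon, a hydrogen in place of methyl on an aromatic carbon, para to a large group. No measured step touches this spot, so nothing shown predicts a direction. The expectation is therefore no step beyond the scatter, a 1.0-fold higher number from compound 1 to compound 3 (0.00 log units; within the scatter), and compound 3 is estimated at 40000 nM, within 15000 nM to 110000 nM.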

Compound 3, half-maximal inhibitory concentration: > 64000 nM
Compound 3: no number, only a limit (the forecaster's own chance of this, stated with the estimate: 15%); middle value at least 1.6-fold (0.20 log units) from the limit.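

Going from 4-methylphenyl to phenyl gives an at least 1.6-fold higher number from compound 1 to compound 3 (0.20 log units; that floor lies within the scatter) and so brings no lower number at this spot, unlike the change on the nitrogen-linked ring. From the compounds shown here alone, since the floor lies within the scatter, the true size of this step stays unknown. Compound 3 has only a limit, not a number: the limit of > 64000 nM in this assay, at which 1 of the 3 values shown sits.

Going by these compounds, whether a methoxy group, a chlorine atom or an amine in place of the methyl would give a lower number stays open. So does how phenyl behaves alongside the 3-chlorophenyl of compound 2.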